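The compounds below may be only part of what the source reports. "The series", "measured", "known", "first", "only" and "open" are said of these compounds alone.

In a functional assay on KYSE-410 cells (Homo sapiens) for antiproliferative activity, read by MTT assay, with a stated time of 72 h (on this read-out lower numbers stand for stronger inhibition and higher numbers for weaker inhibition), compound 1 `O=C(Nc1cc(F)c(F)c(F)c1)c1cc(=O)[nH]c2cc(Br)ccc12` gives a limit rather than a number, > 20000 nM. Compound 2 `O=C(Nc1cc(F)cc(F)c1)c1cc(=O)[nH]c2cc(Cl)ccc12` gives 11000 nM and compound 3 `O=C(Nc1cccc(F)c1)c1cc(=O)[nH]c2cc(-c3ccc(F)cc3)ccc12` gives 10300 nM, and these two numbers lie within the usual scatter of each other. Compound 4 `O=C(Nc1cccc(F)c1)c1cc(=O)[nH]c2cc(C3CC3)ccc12` has cyclopropyl in place of the 4-fluorophenyl of compound 3 on an aromatic carbon (cyclopropyl in place of 4-fluorophenyl on an aromatic carbon). Among the measured compounds shown here, no measured pair isolates this change, so the expectation rests on compound 3, at 10300 nM. The expected step of a 1.1-fold lower number from compound 3 to compound 4 (0.06 log units; within the scatter) in this assay is small, with no clear direction beyond the scatter. For compound 4 the estimated value is 9000 nM, with an expected range from 2500 nM to 20000 nM.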

Compound 4, half-maximal inhibitory concentration: > 20000 nM
Compound 4: only a limit was reported (the forecaster's own chance of this, stated with the estimate: 15%); middle value at least 2.2-fold (0.34 log units) from the limit.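

This is the only comparison shown that changes a single group at this position: cyclopropyl in place of 4-fluorophenyl gives an at least 1.9-fold higher number from compound 3 to compound 4 (0.28 log units; that floor lies within the scatter) in this assay on this aromatic carbon. Compound 4 gives > 20000 nM as a limit of the assay and not a number. As far as these compounds go, the smaller ring brings no lower number here, but the true size of the step stays unknown, because the read-out ends at a limit: the limit of > 20000 nM in this assay, at which 2 of the 4 values shown sit.

From the compounds shown here alone, how an amine, a methoxy group or a plain phenyl would read on this carbon stays open. So does whether the fluorine of the 4-fluorophenyl matters to the number of compound 3.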